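The source may report more compounds than this note shows. Statements on the series, on what has been measured and on what is new or still open speak of the compounds shown alone.

Three compounds share one core and differ only in the group attached to an aromatic nitrogen of the triazole ring. Compound 1 `COc1ccccc1-n1cc(CN2C(=O)C[C@@H]3CC[C@@]2(C)C3(C)C)nn1` carries a 2-methoxyphenyl there; in a functional assay on A549 cells (Homo sapiens) for inhibition, read by MTT assay, with a stated time of 24 h (on this read-out higher numbers stand for weaker inhibition and lower numbers for stronger inhibition), compound 1 gives 350 nM. Compound 2 `Cc1ccc(-n2cc(CN3C(=O)C[C@@H]4CC[C@@]3(C)C4(C)C)nn2)cc1` carries a 4-methylphenyl, and in this assay compound 2 gives 400 nM, the highest of the three numbers, although it and compound 1 sit within the scatter of each other, as the step of a 1.1-fold higher number from compound 1 to compound 2 (0.06 log units; within the scatter) shows. Compound 3 `CC1(C)[C@H]2CC[C@]1(C)N(Cc1cn(-c3ccc(Br)cc3)nn1)C(=O)C2` carries a 4-bromophenyl and gives 80 nM; the step of a 5.0-fold lower number from compound 2 to compound 3 (0.70 log units; beyond the scatter) is the only one beyond the scatter that touches compound 2.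

Compound 4 `Cc1cccc(-n2cc(CN3C(=O)C[C@@H]4CC[C@@]3(C)C4(C)C)nn2)c1` is not yet measured. The change from compound 2 is 3-methylphenyl in place of 4-methylphenyl on an aromatic nitrogen; the two have the same atoms, joined differently. For the measured compounds named here, no measured step moves a methyl from one position of this phenyl to another. The nearest guide is the step of a 1.1-fold higher number from compound 1 to compound 2 (0.06 log units; within the scatter), where a different substituent and position on the same phenyl changed the number within the scatter only. The expectation is therefore a step of a 1.1-fold lower number from compound 2 to compound 4 (0.06 log units; within the scatter) that stays within the scatter, in either direction. For compound 4 the estimated value is 350 nM, with a range from 150 nM to 800 nM.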

Compound 4, half-maximal inhibitory concentration: 50 nM
Compound 4: the middle estimate sits 7.0-fold (0.85 log units) above what was measured, outside the stated range (below it).
By their numbers in this assay, from the lowest: compounds 4 and 3 (each within the scatter of the next); then compounds 1 and 2 (each within the scatter of the next).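

Moving the methyl on the phenyl, with the atoms otherwise unchanged, gives an 8.0-fold lower number from compound 2 to compound 4 (0.90 log units; beyond the scatter) in this assay, so the place of one small group on this ring can matter on its own, which the earlier steps could not show because they changed the group and its place together. The result also ends any impression that only the bromo of compound 3 reaches this range: the step of a 1.6-fold lower number from compound 3 to compound 4 (0.20 log units; within the scatter) keeps the two together, while a 7.0-fold lower number from compound 1 to compound 4 (0.85 log units; beyond the scatter) sets compound 4 clearly apart from the 2-methoxyphenyl compound. Nothing available here explains this difference.

Going by these compounds, whether an ethyl, an amine or a carboxylic acid in place of the methyl of the 3-methylphenyl would keep this number remains open. Also open, on these data alone, is whether moving the bromo of compound 3 on its ring would shift the number as much.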